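Notes on the series: isopropyl in place of amino

A few compounds are considered here, and "the series" means these few. Any claim that something is new, unique, unknown or untested is made for them only; others in the source may bear on it.

Going by the values given here, compound 2 `CCCS(=O)(=O)Nc1ccc(F)c(C(=O)c2n[nH]c3ncc(-c4ccc(N)cc4)cc23)c1F` gives 0.1% in an assay for binding affinity to dual specificity mitogen-activated protein kinase kinase 4 (Homo sapiens), read by KINOMEscan, tested at 100 nM (on this read-out lower numbers stand for a stronger effect and higher numbers for a weaker effect at the one concentration tested), and so carries the lowest of the two numbers known so far; its nearest neighbour is compound 1 `CCCS(=O)(=O)Nc1ccc(F)c(C(=O)c2n[nH]c3ncc(-c4ccc(C)cc4)cc23)c1F`, which gives 5.4% in this assay. Among the compounds with values here, the only measured step, a number 5.3 percentage points lower from compound 1 to compound 2 (within the scatter), covers amino in place of methyl on an aromatic carbon and stays within the scatter, so both compounds sit near the bottom of the read-out.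

Compound 3 `CCCS(=O)(=O)Nc1ccc(F)c(C(=O)c2n[nH]c3ncc(-c4ccc(C(C)C)cc4)cc23)c1F` differs from compound 2 by isopropyl in place of amino on an aromatic carbon. Within the data shown here, no measured step covers isopropyl at this carbon; the one step known, a number 5.3 percentage points lower from compound 1 to compound 2 (within the scatter), shows that exchanging groups here left the number within the scatter. On that basis no step beyond the scatter is expected, a number 3.9 percentage points higher from compound 2 to compound 3 (within the scatter). For compound 3 the estimate in this assay is 4%, with a range from 0% to 15%.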

Compound 3, a percentage reported as activity, at one concentration (the size of the read-out at that concentration, not a potency): 17%
Compound 3: the middle estimate sits 13 percentage points below what was measured, and the stated range ends below it.
By their numbers in this assay, from the lowest: compounds 2 and 1 (each within the scatter of the next); then compound 3.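

Isopropyl is the first group at this aromatic carbon, para to a large group, to move the read-out in this assay beyond the scatter: the change gives a number 16.9 percentage points higher from compound 2 to compound 3 (beyond the scatter) and also a number 11.6 percentage points higher from compound 1 to compound 3 (beyond the scatter) in the series. Going by these compounds alone, both steps are modest, but they show that this position is not indifferent to the group it carries, as the single step between compound 1 and compound 2 had left possible. Among these three compounds, isopropyl alone stands apart, and nothing measured here accounts for the shift.

Ethyl, tert-butyl, hydroxyl or a carboxylic acid at this carbon could show whether other groups fall with compound 3 or with compound 1 and compound 2. On these data alone, with readings at a single concentration, how far these differences carry over to potency also stays open.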